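This account rests on a few compounds, and the source may have more. Where it says the series, first, only, none or still open, it means among the compounds named here.

Values in a functional assay on NUGC-3 cells (Homo sapiens) for antiproliferative activity, read by sulforhodamine B assay (a lower number here means a stronger inhibitor of growth, a higher number a weaker inhibitor of growth), are as follows.

Compound 1 `CC(C)(C)CCOc1cccc(O)c1C(=O)/C=C/c1ccc(C(=O)O)cc1` gives 5440 nM
Compound 2 `CC(C)(C)CCOc1cccc(O)c1C(=O)/C=C/c1ccc(O)cc1` gives 3300 nM
Compound 3 `CCC(CC)COc1cccc(O)c1C(=O)/C=C/c1ccc(O)cc1` gives 1960 nM

Compound 2 sits within the scatter of both other compounds (a 1.6-fold lower number from compound 1 to compound 2 (0.22 log units; within the scatter) and a 1.7-fold lower number from compound 2 to compound 3 (0.23 log units; within the scatter)). Compound 4 `CC(C)(C)CCOc1cccc(O)c1C(=O)/C=C/c1ccc(S(N)(=O)=O)cc1` carries sulfamoyl in place of hydroxy on an aromatic carbon, para to a large group. The measured step that bears on this carbon is the exchange of carboxy for hydroxy (a 1.6-fold lower number from compound 1 to compound 2 (0.22 log units; within the scatter)), while the other step concerns the chain and bears on it only loosely. No change beyond the scatter is therefore expected, and the estimated step is a 1.2-fold higher number from compound 2 to compound 4 (0.08 log units; within the scatter) in this assay. For compound 4 the estimated value is 4000 nM with an expected range from 1500 nM to 11000 nM in this assay when measured.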

Compound 4, concentration for 50% growth inhibition: 1170 nM
Compound 4: middle estimate off by 3.4-fold (0.53 log units), on the high side; the measured number lies below the stated range.
By their numbers in this assay, from the lowest: compounds 4, 3, 2 and 1 (each within the scatter of the next, the first and the last beyond it).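

In this assay, the aromatic carbon para to a large group now shows a change beyond the scatter: sulfamoyl in place of hydroxy gives a 2.8-fold lower number from compound 2 to compound 4 (0.45 log units; beyond the scatter) and sulfamoyl in place of carboxy gives a 4.6-fold lower number from compound 1 to compound 4 (0.67 log units; beyond the scatter) at this same carbon. The exchange of carboxy for hydroxy had stayed within the scatter, so only sulfamoyl separates itself here. Going by these compounds, whether an amine or a methylsulfonyl group at this carbon would behave like sulfamoyl, and whether sulfamoyl would do the same with the pentan-3-yl chain of compound 3, remains open. Nothing available explains this step.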